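This account rests on a few compounds, and the source may have more. Where it says the series, first, only, none or still open, it means among the compounds named here.

This account follows one substitution within a small set of related compounds that share a common core and differ only in the aromatic group carried on the amine nitrogen in a ring. Compound 1 `CC1(c2ccccc2)CC(=O)N(CC(=O)N2CCN(c3ccccc3F)CC2)C1=O` was examined in a functional assay on the whole organism (strain CD-1) with Mus musculus as the target, in the maximal electroshock model, with a stated time of 0.5 h (a higher number here means that more compound is needed for the effect, a lower number that less compound is needed), and gave 100 mg/kg. Compound 2 `CC1(c2ccccc2)CC(=O)N(CC(=O)N2CCN(c3cccc(Cl)c3Cl)CC2)C1=O`, which carries the 2,3-dichlorophenyl group, was recorded in this assay as "not active" (no number reported), so no single number exists for compound 2 and its place on the scale cannot be stated; it can only be said that compound 1 shows an effect at its dose where compound 2 shows none.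

Compound 3 `CC1(c2ccccc2)CC(=O)N(CC(=O)N2CCN(c3ccc(F)cc3)CC2)C1=O` has not yet been measured. It differs from compound 2 in one place: 4-fluorophenyl in place of 2,3-dichlorophenyl on an amine nitrogen in a ring. Among the compounds with values here, no measured step connects compound 2 to compound 3, so the size of the change in this assay cannot be read from the data; the expectation is that compound 3 will move toward the behaviour of compound 1, which gave 100 mg/kg, rather than stay inactive. The estimate for compound 3 in this assay is 100 mg/kg, with a range from 30 mg/kg to 300 mg/kg.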

Compound 3, minimum effective dose: 100 mg/kg
For compound 3 middle estimate and measured number coincide at the digits printed; measured number inside the range.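

In this assay there is no change at the digits printed from compound 1 to compound 3 (within the scatter), so at this place on the amine nitrogen in a ring, the two fluorophenyl groups cannot be told apart in this assay. This gives a second compound with a number in the series: compound 3 gives 100 mg/kg, while compound 2 has none, so the step from compound 2 to compound 3 cannot be read as a size. Among these three compounds, both fluorophenyl groups go with an effect at the recorded dose and the 2,3-dichlorophenyl group does not, but 2,3-dichlorophenyl differs from them in both the kind of halogen and the number of halogens, so the two differences cannot be separated.

The compounds shown leave open whether a plain phenyl group, a 4-chlorophenyl group or a 4-methoxyphenyl group at this place would give a number in this assay or would be recorded as not active, as compound 2 was. Nothing measured here offers an explanation for the result.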